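Ethyl to tert-butyl on the aromatic carbon: solubility outlook

The compounds below may be only part of what the source reports. "The series", "measured", "known", "first", "only" and "open" are said of these compounds alone.

Compound 2 `CCc1ccc2c(c1)[n+]([O-])c(NCCN(C)C)n[n+]2[O-]` carries an ethyl group on an aromatic carbon of the shared core. In a physicochemical assay for solubility, in the presence of a further agent that is not named here (on this read-out lower numbers stand for lower solubility and higher numbers for higher solubility), compound 2 gives > 49000000 nM, which is a limit of the assay and not a number. Compound 1 `CN(C)CCNc1n[n+]([O-])c2ccccc2[n+]1[O-]` has hydrogen in place of that ethyl. In this assay compound 1 gives 50000000 nM. The step that the limit leaves unreadable from compound 1 to compound 2 cannot be sized because of the limit of > 49000000 nM in this assay, at which 1 of the 2 values shown sits.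

Compound 3 `CN(C)CCNc1n[n+]([O-])c2ccc(C(C)(C)C)cc2[n+]1[O-]` has not yet been measured. It differs from compound 2 by tert-butyl in place of ethyl on an aromatic carbon, in words tert-butyl in place of ethyl on an aromatic carbon. Going by the values given here, the only measured step that bears on this change is a step that the limit leaves unreadable from compound 1 to compound 2, and its size is unreadable; no measured pair shows what a larger alkyl group at this aromatic carbon does to the read-out. The expectation for compound 3 is therefore a step of an at least 1.0-fold lower number from compound 2 to compound 3 (0.03 log units; that floor lies within the scatter) in this assay, not beyond the scatter, with a fair chance that the assay again reports only a limit. The estimate for compound 3 is 45000000 nM, with a range from 20000000 nM to 100000000 nM.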

Compound 3, solubility: 38000000 nM
For compound 3 the middle estimate is 1.2-fold (0.07 log units) above the measured one; the range from low to high includes it.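

With tert-butyl on this aromatic carbon, this assay returns a number and not a limit, and against hydrogen on the same carbon the read-out gives a 1.3-fold lower number from compound 1 to compound 3 (0.12 log units; within the scatter), so for this pair the addition of the tert-butyl group stays inside the usual scatter. Against ethyl, the change gives an at least 1.2-fold lower number from compound 2 to compound 3 (0.11 log units; that floor lies within the scatter), which is a floor and not a full size, and that floor also lies within the scatter. The step from hydrogen to ethyl cannot be read, and the step from ethyl to tert-butyl has only its floor, because the value of compound 2 is a limit: the limit of > 49000000 nM in this assay, at which 1 of the 3 values shown sits.

Only hydrogen, ethyl and tert-butyl are shown on this aromatic carbon, so it stays open whether any group there, such as an amine or a carboxylic acid, moves the read-out beyond the scatter. The shared core and its side chain are also unchanged across the compounds shown, which leaves open what a longer chain in that side chain would do in this assay.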